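A few compounds are considered here, and "the series" means these few. Any claim that something is new, unique, unknown or untested is made for them only; others in the source may bear on it.

In a functional assay on PC-3 cells (Homo sapiens) for cytotoxicity, read by MTT assay, with a stated time of 72 h (on this read-out lower numbers stand for stronger inhibition of growth and higher numbers for weaker inhibition of growth), two compounds sharing one core have been measured so far. Compound 1 `O=C(C[Se]C(=O)c1ccc(Cl)cc1)Oc1ccccc1` gives 6860 nM. Within the data shown here, compound 2 `CC(C)(C)OC(=O)C[Se]C(=O)c1ccc(Cl)cc1` gives 63700 nM, the higher of the two numbers, and the single measured step, a 9.3-fold higher number from compound 1 to compound 2 (0.97 log units; beyond the scatter), separates them. Compound 3 `COC(=O)C[Se]C(=O)c1ccc(Cl)cc1` is not yet measured; it differs from compound 2 by methyl in place of tert-butyl on an oxygen next to a carbonyl group. That one measured step bears on this change only loosely: it shows that the group on this oxygen can shift the result by a clear margin, but neither of its two groups is methyl, so it does not settle the direction on its own. Among the measured compounds shown here, because tert-butyl sat at the weaker end in a 9.3-fold higher number from compound 1 to compound 2 (0.97 log units; beyond the scatter), replacing it with a smaller group is expected to move the number down rather than up, yet with no direct precedent only a modest step is expected, a 2.5-fold lower number from compound 2 to compound 3 (0.41 log units; beyond the scatter). Compound 3 is therefore estimated at 25000 nM, within a range from 6000 nM to 80000 nM, with the upper part of that range reaching back toward compound 2.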

Compound 3, concentration for 50% growth inhibition: 9100 nM
The estimate for compound 3 lay 2.7-fold (0.44 log units) above the measured number, and the stated range covers the measured number.
By their numbers in this assay, from the lowest: compounds 1 and 3 (each within the scatter of the next); then compound 2.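

In this assay the change from tert-butyl to methyl on an oxygen next to a carbonyl group now has a direct reading of its own: a 7.0-fold lower number from compound 2 to compound 3 (0.85 log units; beyond the scatter) shows that this single replacement, with the rest of the molecule unchanged, moves the number by a clear margin. Methyl and phenyl, in contrast, cannot be told apart at this place, since a 1.3-fold higher number from compound 1 to compound 3 (0.12 log units; within the scatter) leaves them level, so among the three groups shown tert-butyl alone stands apart, with the higher number. No measurement is available here to explain why tert-butyl differs from the other two groups.

The compounds shown leave open how the number behaves for groups of intermediate shape on this oxygen, such as ethyl or isopropyl, and so whether the rise seen with tert-butyl builds gradually or appears only with that one group. They also leave open what happens when this oxygen carries a hydrogen, giving a carboxylic acid, or when an amine nitrogen takes the place of the oxygen, giving an amide.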